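Halogen swap at the benzyl para position of a thiolactam ether

The compounds below may be only part of what the source reports. "The series", "measured", "known", "first", "only" and "open" are said of these compounds alone.

Measured so far:
compound 1 `O=C1CSc2cc(OCc3ccc(Cl)cc3)ccc2N1` — 2.7 nM
compound 2 `N#Cc1ccc(COc2ccc3c(c2)SCC(=O)N3)cc1` — 9.6 nM

In an assay on isolated protein for inhibition of Amine oxidase [flavin-containing] B (Homo sapiens), read by fluorescence and spectrophotometry, with a stated time of 20 min (on this read-out higher numbers stand for weaker inhibition and lower numbers for stronger inhibition), compound 1 gives 2.7 nM and compound 2 gives 9.6 nM, so compound 2 holds the higher of the two numbers. Within the data shown here, the single measured step, a 3.6-fold higher number from compound 1 to compound 2 (0.55 log units; beyond the scatter), shows the cyano analogue as the weaker of the pair. Compound 3 `O=C1CSc2cc(OCc3ccc(Br)cc3)ccc2N1` carries bromo in place of cyano on an aromatic carbon. Bromo returns a halogen where compound 1 already carries chloro, so the expected step of a 3.2-fold lower number from compound 2 to compound 3 (0.51 log units; beyond the scatter) roughly reverses the measured one. Compound 3 is therefore estimated at 3 nM, with a range of 1.2 nM to 8 nM.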

Compound 3, half-maximal inhibitory concentration: 4.1 nM
Compound 3: the middle estimate sits 1.4-fold (0.14 log units) below what was measured, within the range that was stated.
By their numbers in this assay, from the lowest: compounds 1 and 3 (each within the scatter of the next); then compound 2.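

In this assay, the change from cyano to bromo on this aromatic carbon gives a 2.3-fold lower number from compound 2 to compound 3 (0.37 log units; beyond the scatter) and lies beyond the scatter. The swap between the two halogens gives a 1.5-fold higher number from compound 1 to compound 3 (0.18 log units; within the scatter) and stays within the scatter, so chloro and bromo cannot be told apart here, while cyano stands apart from both. No evidence offered here accounts for this difference. As far as these compounds go, it remains open whether fluoro or iodo would stay with chloro and bromo, and whether an amine, a methoxy group or a carboxylic acid on this carbon would fall with cyano or apart from both.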